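From Isopropyl to 2-Methoxyethyl on Compound 1

This account rests on a few compounds, and the source may have more. Where it says the series, first, only, none or still open, it means among the compounds named here.

In an ADME assay on S9 fraction from S9 cells (Zone of skin, Homo sapiens) for metabolic stability, read by HPLC, with a stated time of 180 min, tested at 0.5 uM (on this read-out higher numbers stand for a longer-lived compound and lower numbers for a shorter-lived compound), compound 1 (`CCC/N=C1\S/C(=C\c2ccc(OC(=O)C(C)C)c(C)c2)C(=O)N1c1ccccc1C`) gives 0.35 h as the higher of the two measured numbers. Compound 2 (`CCC/N=C1\S/C(=C\c2ccc(OC(C)=O)c(Br)c2)C(=O)N1c1ccccc1C`) gives 0.147 h and that gap lies beyond the scatter. Compound 3 (`CCC/N=C1\S/C(=C\c2ccc(OC(=O)CCOC)c(C)c2)C(=O)N1c1ccccc1C`) is compound 1 with 2-methoxyethyl in place of isopropyl on a carbonyl carbon. Within the data shown here, no measured pair shows this change alone, so only a modest drop in this assay is expected, close to the scatter. The expected step is a 1.8-fold lower number from compound 1 to compound 3 (0.24 log units; within the scatter) and it remains an estimate. Compound 3 is estimated at 0.2 h within an expected range of 0.07 h to 0.5 h in this measurement.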

Compound 3, half-life: 0.08 h
The estimate for compound 3 lay 2.5-fold (0.40 log units) above the measured number; low and high end bracket the measured number.
By their numbers in this assay, from the lowest: compounds 3 and 2 (each within the scatter of the next); then compound 1.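

At this position, the group on the carbonyl carbon clearly affects the result in this assay: 2-methoxyethyl in place of isopropyl gives a 4.4-fold lower number from compound 1 to compound 3 (0.64 log units; beyond the scatter). Among these compounds, this is the first single change the series offers, and its size shows that the half-life is sensitive to this group alone. No available evidence accounts for the fall.

The compounds shown do not separate the oxygen in the chain from the chain's length. On these data alone, how a plain butyl chain, a longer ether chain or an amine on the same carbonyl carbon would compare remains open.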